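A few compounds are considered here, and "the series" means these few. Any claim that something is new, unique, unknown or untested is made for them only; others in the source may bear on it.

Among the measured compounds shown here, the three compounds measured so far share one core and differ only in the substitution of the terminal aryl ring. Compound 1, `O=C(Nc1cccc(-n2cc(-c3ccncc3)c(-c3ccc(Cl)c(O)c3)n2)c1)Nc1ccc(Cl)c(Cl)c1`, was tested in a functional assay on 786-0 cells (Homo sapiens) for inhibition, read by sulforhodamine B assay, with a stated time of 48 h (on this read-out lower numbers stand for higher toxicity in this test and higher numbers for lower toxicity in this test), and returned only a limit of > 32500 nM, a bound of the assay rather than a number. Compound 3, `COc1cc(-c2nn(-c3cccc(NC(=O)Nc4ccc(Cl)c(C(F)(F)F)c4)c3)cc2-c2ccncc2)ccc1Cl`, likewise stopped at a limit of > 32500 nM. For the measured compounds named here, compound 2, `O=C(Nc1cccc(-n2cc(-c3ccncc3)c(-c3ccc(Cl)c(O)c3)n2)c1)Nc1cc(C(F)(F)F)cc(C(F)(F)F)c1`, is the only member of the set to give a number in this assay, where compound 2 gives 18000 nM. Compounds 1 and 3 together account for (the limit of > 32500 nM in this assay, at which 2 of the 3 values shown sit), so compound 2 stands alone as the one measurable toxicity in this group.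

Compound 4, `O=C(Nc1cccc(-n2cc(-c3ccncc3)c(-c3ccc(Cl)c(O)c3)n2)c1)Nc1cccc(C(F)(F)F)c1`, is not yet measured. It differs from compound 2 by hydrogen in place of trifluoromethyl on an aromatic carbon. Going by the values given here, no step between two measured compounds is available to guide the expectation. Among the compounds with values here, what the numbers show is that the only compound with a reading is the one carrying two trifluoromethyl groups, while the two differently substituted analogues stayed at the limit. Removing one trifluoromethyl is therefore expected to weaken the toxicity, with the number moving upward from compound 2 to compound 4 by a 1.7-fold higher number from compound 2 to compound 4 (0.22 log units; within the scatter), a step that may well exceed the usual scatter. Compound 4 is estimated at 30000 nM, within a range of 15000 nM to 60000 nM, and there is a real chance that only a limit will be recorded.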

Compound 4, concentration lethal to 50% of the cells: > 32500 nM
Compound 4 was reported as a limit (the forecaster's own chance of this, stated with the estimate: 50%); middle value at least 1.0-fold (0.03 log units) from the limit.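

With hydrogen in place of trifluoromethyl on an aromatic carbon, the series gains its first step that changes one place only: in this assay the move is an at least 1.8-fold higher number from compound 2 to compound 4 (0.25 log units; that floor lies within the scatter). Going by these compounds, compound 4 ends at a limit, so this figure is only a floor, and the true size of the step remains unknown. This single trifluoromethyl group is now the only structural difference between the one compound with a number and a compound with no number, and the series as a whole reads: the limit of > 32500 nM in this assay, at which 3 of the 4 values shown sit.

The step from compound 1 to compound 4 cannot be read, as both values are limits, so the 3,4-dichlorophenyl and 3-(trifluoromethyl)phenyl groups cannot be ranked against each other. On these data alone, it remains open whether an amine, a nitrile or a methyl group on this aromatic carbon would give a number in this assay, and whether any such reading would differ from that of compound 2 by more than the usual scatter.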